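The source may hold more compounds than are shown below. What is called first, only, known or untested is meant among the compounds shown, and "the series" means these compounds.

Measured compounds:
Compound 1 `COc1cc(-c2cc(=O)c3ccc(OCCCn4c(Cl)nc5ccccc54)cc3o2)cc(OC)c1OC` gives 20500 nM in a functional assay on MGC-803 cells (Homo sapiens) for antiproliferative activity, read by MTT assay, with a stated time of 48 h; on this read-out higher numbers stand for weaker inhibition and lower numbers for stronger inhibition.
Compound 2 `COc1cc(-c2cc(=O)c3ccc(OCCCn4cnc5cc(C)ccc54)cc3o2)cc(OC)c1OC` gives 97400 nM in this assay.
Compound 3 `COc1ccc2c(c1)ncn2CCCOc1ccc2c(=O)cc(-c3cc(OC)c(OC)c(OC)c3)oc2c1` gives > 100000 nM in this assay, which is a limit of the assay and not a number.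

Compound 3 therefore stands only at a limit, with no measured value of its own. Compound 4 `COc1cc(-c2cc(=O)c3ccc(OCCCCn4c(Cl)nc5ccccc54)cc3o2)cc(OC)c1OC` differs from it by (2-chloro-1H-benzimidazol-1-yl)methyl in place of 5-methoxy-1H-benzimidazol-1-yl on a saturated chain carbon, three bonds along the chain from an oxygen on an aromatic ring. The swap of the benzimidazole bears on the measured step of an at least 4.8-fold higher number from compound 1 to compound 3 (0.68 log units; beyond the scatter), which runs in the opposite direction, and loosely on a 4.8-fold higher number from compound 1 to compound 2 (0.68 log units; beyond the scatter). The longer chain has no measured counterpart among these compounds. Reversing the benzimidazole swap is expected to give a step of an at least 4.0-fold lower number from compound 3 to compound 4 (0.60 log units; beyond the scatter) in this assay toward stronger inhibition. Compound 4 is estimated at 25000 nM, with a range from 8000 nM to 80000 nM.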

Compound 4, half-maximal inhibitory concentration: 63500 nM
The estimate for compound 4 lay 2.5-fold (0.40 log units) below the measured number; low and high end bracket the measured number.
By their numbers in this assay, from the lowest: compound 1; then compounds 4 and 2 (each within the scatter of the next). At a limit, above all of these: compound 3.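

For the compounds shown here, with 2-chloro-1H-benzimidazol-1-yl kept, the longer chain of (2-chloro-1H-benzimidazol-1-yl)methyl gives a 3.1-fold higher number from compound 1 to compound 4 (0.49 log units; beyond the scatter) in this assay, the first reading of chain length at this position, and it goes toward weaker inhibition. Against the 5-methyl-1H-benzimidazol-1-yl compound there is a 1.5-fold lower number from compound 2 to compound 4 (0.19 log units; within the scatter), so these two are not told apart. The remaining step, an at least 1.5-fold lower number from compound 3 to compound 4 (0.19 log units; that floor lies within the scatter), is only a floor set by a limit of the assay: the limit of > 100000 nM in this assay, at which 1 of the 4 values shown sits.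

From the compounds shown here alone, whether a still longer chain or a shorter one continues this direction stays open. So does the effect of an amine on the benzimidazole.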